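Replacing the enol hydroxy of compound 1 with an arylamino group

A few compounds are considered here, and "the series" means these few. Any claim that something is new, unique, unknown or untested is made for them only; others in the source may bear on it.

Going by the values given here, the three measured members share a core that carries a benzoyl group, a 4-bromophenyl group and a 3-(1H-imidazol-1-yl)propyl group, and differ only at the oxygen on the double-bonded ring carbon. Compound 1 `O=C(C1=C(O)C(=O)N(CCCn2ccnc2)C1c1ccc(Br)cc1)c1ccccc1` bears the free hydroxy there. In a functional assay on NCI-H1299 cells (Homo sapiens) for antiproliferative activity, read by MTT assay, with a stated time of 72 h (on this read-out higher numbers stand for weaker inhibition and lower numbers for stronger inhibition), compound 1 gives 20000 nM, the highest of the three numbers, although both other members lie within the scatter of it. Compound 2 `CCCCCOC1=C(C(=O)c2ccccc2)C(c2ccc(Br)cc2)N(CCCn2ccnc2)C1=O` gives 10300 nM and compound 3 `O=C(C1=C(OC2CCCCC2)C(=O)N(CCCn2ccnc2)C1c1ccc(Br)cc1)c1ccccc1` gives 19900 nM. The measured steps are small: a 1.9-fold lower number from compound 1 to compound 2 (0.29 log units; within the scatter); a 1.0-fold lower number from compound 1 to compound 3 (0.00 log units; within the scatter); a 1.9-fold higher number from compound 2 to compound 3 (0.29 log units; within the scatter).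

Compound 4 `O=C(C1=C(Nc2ccc(I)cc2)C(=O)N(CCCn2ccnc2)C1c1ccc(Br)cc1)c1ccccc1` differs from compound 1 by (4-iodophenyl)amino in place of hydroxy on a double-bonded ring carbon. Among the compounds with values here, no measured step exchanges the hydroxy for the (4-iodophenyl)amino group; the steps from compound 1 to compound 2 and to compound 3 only replace the hydrogen on that oxygen and stay within the scatter, so they give no direction for this change. The step is therefore expected to stay within the scatter, a 1.3-fold lower number from compound 1 to compound 4 (0.12 log units; within the scatter). Compound 4 is thus estimated at 15000 nM, with a range from 5000 nM to 40000 nM.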

Compound 4, half-maximal inhibitory concentration: 19400 nM
The estimate for compound 4 lay 1.3-fold (0.11 log units) below the measured number; the range from low to high includes it.
By their numbers in this assay, from the lowest: compounds 2, 4, 3 and 1 (each within the scatter of the next).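

In this assay, going by these compounds alone, the (4-iodophenyl)amino group is the first member at this position linked through nitrogen rather than oxygen, and each of its steps stays within the scatter: in place of hydroxy (a 1.0-fold lower number from compound 1 to compound 4 (0.01 log units; within the scatter)), in place of cyclohexyloxy (a 1.0-fold lower number from compound 3 to compound 4 (0.01 log units; within the scatter)) and in place of pentyloxy (a 1.9-fold higher number from compound 2 to compound 4 (0.27 log units; within the scatter)). Even the entry of a six-membered aromatic ring, with eight heavy atoms replacing one, therefore leaves the number indistinguishable from those of the three oxygen-bearing compounds. Nothing available explains this flat response.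

On these data alone, whether any group at this position can move the number beyond the scatter remains open, as does the role of the iodine, which an unsubstituted anilino group or a cyclohexylamino group would help to separate. The benzoyl, 4-bromophenyl and 3-(1H-imidazol-1-yl)propyl groups are the same throughout, so their contribution is also unresolved.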